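Lengthening the Amide Chain in a Melatonin Receptor Series

A few compounds are considered here, and "the series" means these few. Any claim that something is new, unique, unknown or untested is made for them only; others in the source may bear on it.

Compound 1, `CCC(=O)NCc1ccc(OC)c(F)c1`: 1050 nM
Compound 2, `COc1ccc(F)c(CCCNC(C)=O)c1`: 20.4 nM
Compound 3, `CCC(=O)NCCCc1cc(OC)ccc1F`: 3.72 nM

Of the compounds shown here, three have so far been measured in an assay on isolated protein for agonist activity at melatonin receptor type 1C (Xenopus laevis), read by spectrophotometry; a lower number here means that less compound is needed, a higher number that more compound is needed for the effect. Compound 1 `CCC(=O)NCc1ccc(OC)c(F)c1` gives 1050 nM, compound 2 `COc1ccc(F)c(CCCNC(C)=O)c1` gives 20.4 nM, and compound 3 `CCC(=O)NCCCc1cc(OC)ccc1F` gives 3.72 nM. Compound 3 thus stands lowest of the three numbers, compound 2 is its nearest neighbour, and compound 1 lies furthest away with the highest number of the set.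

Among the measured compounds shown here, only one step between measured compounds changes a single place: a 5.5-fold lower number from compound 2 to compound 3 (0.74 log units; beyond the scatter). That step grew the acyl group on the amide by one carbon and lowered the number by a modest amount.

Compound 4 `CCCC(=O)NCCCc1cc(OC)ccc1F` differs from compound 3 by methyl in place of hydrogen on a saturated chain carbon, two bonds along the chain from a carbonyl carbon. This repeats the same kind of growth, one bond further out along the chain. For the measured compounds named here, the single step that bears on it points downward, but there is no way to tell from one step whether a second added methyl will continue the trend or flatten out. The expected step is a 1.2-fold lower number from compound 3 to compound 4 (0.09 log units; within the scatter), a small move that stays within the scatter. For compound 4 the estimate in this assay is 3 nM, with a range from 1 nM to 10 nM.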

Compound 4, half-maximal effective concentration: 9.55 nM
Compound 4: the middle estimate sits 3.2-fold (0.50 log units) below what was measured, and the stated range covers the measured number.
By their numbers in this assay, from the lowest: compound 3; then compound 4; then compound 2; then compound 1.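

In this assay, methyl in place of hydrogen at this place on the chain does not repeat the earlier gain: propanoyl to propylcarbonyl gives a 2.6-fold higher number from compound 3 to compound 4 (0.41 log units; beyond the scatter), a change in the opposite direction to a 5.5-fold lower number from compound 2 to compound 3 (0.74 log units; beyond the scatter) at the carbon one bond closer to the carbonyl. Ethyl in place of hydrogen on the saturated chain carbon bound to the carbonyl carbon still gives a 2.1-fold lower number from compound 2 to compound 4 (0.33 log units; beyond the scatter) overall, so the longest of the three acyl chains keeps part of the gain but not all of it. Among these three compounds, the number therefore does not move in one direction as the chain grows, and compound 3 has the lowest number of the series, while no measurement here explains the reversal.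

A longer chain on the carbonyl could raise the number further or leave it level, and the three compounds cannot separate those outcomes. Going by these compounds, it also remains open how a branched isopropyl group or a cyclopropyl ring in the same place would compare with the propanoyl group of compound 3.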